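A Benzyl Ester Variant of a Dimethyl Diester Antagonist

The compounds below may be only part of what the source reports. "The series", "measured", "known", "first", "only" and "open" are said of these compounds alone.

Compound 1 `COC(=O)C1=C(C)NC(C)=C(C(=O)OC)C1c1csc(-c2ccc(Cl)cc2)n1` and compound 2 `CC1=C(C(=O)OC2CCCCC2)C(c2csc(-c3ccc(Cl)cc3)n2)C(C(=O)OC2CCCCC2)=C(C)N1` share the same core and have both been examined in an assay on isolated protein for antagonist activity at Voltage-dependent L-type calcium channel subunit alpha-1C (Cavia porcellus), with a stated time of 15 min; on this read-out lower numbers stand for stronger inhibition and higher numbers for weaker inhibition. For the measured compounds named here, compound 1 gives 4430 nM in this assay, the lowest of the two numbers available so far. Compound 2 gives 11000 nM in this assay, and the gap between the two values lies beyond the usual scatter of repeated measurements, so compound 2 is the weaker of the pair.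

Compound 3 `COC(=O)C1=C(C)NC(C)=C(C(=O)OCc2ccccc2)C1c1csc(-c2ccc(Cl)cc2)n1` has not yet been measured in this assay. Set against compound 1, compound 3 carries phenyl in place of hydrogen on a saturated chain carbon bound to an oxygen next to a carbonyl group. Going by the values given here, no pair of measured compounds differing in a single place is available, so the effect of this exchange cannot be read from a measured step, and the only guide is the pair of values for compound 1 and compound 2.

The author expects the step of a 1.5-fold lower number from compound 1 to compound 3 (0.17 log units; within the scatter) to be small, not clearly beyond the scatter, with a slight lean toward a lower number. Compound 3 is accordingly estimated at 3000 nM in this assay, within a range from 1000 nM to 9000 nM.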

Compound 3, half-maximal inhibitory concentration: 64900 nM
Beside the measured number, compound 3's estimate is 22-fold (1.34 log units) below it, and the stated range ends below it.
By their numbers in this assay, from the lowest: compound 1; then compound 2; then compound 3.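

Changing methyl to benzyl, and so methoxycarbonyl to benzyloxycarbonyl, gives a 15-fold higher number from compound 1 to compound 3 (1.17 log units; beyond the scatter) in this assay, which means weaker inhibition. For the compounds shown here, this is the first direct reading of a single change at this place, since compound 1 and compound 2 differ in more than one place and their values could not isolate one exchange. It shows that this position is not indifferent to the change: phenyl in place of hydrogen on this saturated chain carbon bound to an oxygen weakens inhibition well beyond the usual scatter, and nothing available here accounts for the loss.

The compounds shown leave open whether the loss belongs to phenyl in particular or would also follow from an ethyl group, a longer chain or a chain ending in an amine at the same place. A single step also cannot tell whether a phenyl ring carrying a chlorine or a methoxy group would sit closer to compound 1 or to compound 3.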